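Double-bond isomers with and without the hydroxy

The source may report more compounds than this note shows. Statements on the series, on what has been measured and on what is new or still open speak of the compounds shown alone.

- compound 1 `CC/C(=C(\c1ccccc1)c1ccc(NC(=O)C(C)C)cc1)c1ccc(Cl)cc1Cl` gives 8300 nM
- compound 2 `CC/C(=C(/c1ccccc1)c1ccc(NC(=O)C(C)C)cc1)c1ccc(Cl)cc1Cl` gives 17500 nM
- compound 3 `CC/C(=C(\c1ccc(O)cc1)c1ccc(NC(=O)C(C)C)cc1)c1ccc(Cl)cc1Cl` gives 12500 nM

In a functional assay on MCF7 cells (Homo sapiens) for inhibition, read by trypan blue exclusion, with a stated time of 72 h (a higher number here means a weaker inhibitor of growth, a lower number a stronger inhibitor of growth), compound 3 lies within the scatter of both compound 1 and compound 2, with a 1.5-fold higher number from compound 1 to compound 3 (0.18 log units; within the scatter) for hydroxy in place of hydrogen on an aromatic carbon. The next change, to compound 4 `CC/C(=C(/c1ccc(O)cc1)c1ccc(NC(=O)C(C)C)cc1)c1ccc(Cl)cc1Cl`, is this: the two compounds have the same atoms and bonds and differ only in configuration as drawn: 1 of 1 stereo elements differ; a double bond is drawn E in compound 3 and Z in compound 4 and nothing else. The one measured inversion at this double bond is a 2.1-fold higher number from compound 1 to compound 2 (0.32 log units; beyond the scatter) in the pair without the hydroxy, where the fact that compounds 1 and 2 differ only in the configuration as drawn leaves configuration as the only difference. Compound 3 keeps the arrangement of compound 1 despite its different letter, so a step of similar size towards a higher number is expected in this assay, estimated as a 1.7-fold higher number from compound 3 to compound 4 (0.23 log units; within the scatter) for now. Compound 4 is expected at 21000 nM with an estimated range from 11000 nM to 38000 nM in this read-out.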

Compound 4, concentration for 50% growth inhibition: 26600 nM
Compound 4: middle estimate off by 1.3-fold (0.10 log units), on the low side, within the range that was stated.
By their numbers in this assay, from the lowest: compounds 1, 3, 2 and 4 (each within the scatter of the next, the first and the last beyond it).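

In this assay the double-bond inversion now appears a second time, with a 2.1-fold higher number from compound 3 to compound 4 (0.33 log units; beyond the scatter) in the hydroxy pair, in the same direction as in the pair without the hydroxy, and only configuration separates these two: the fact that compounds 3 and 4 differ only in the configuration as drawn.

Hydroxy in place of hydrogen stays within the scatter on the other isomer too, with a 1.5-fold higher number from compound 2 to compound 4 (0.18 log units; within the scatter), and the two hydroxy steps agree: the same change on two cores in this assay, a 1.5-fold higher number (0.18 log units; within the scatter) from compound 1 to compound 3 and a 1.5-fold higher number (0.18 log units; within the scatter) from compound 2 to compound 4, 1.0-fold (0.00 log units) apart, within the scatter of two such steps.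

Still open, going by these compounds, is how an amine or a carboxylic acid in place of the hydroxy would read in this assay, and whether either isomer preference would persist with such a group.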